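This account rests on a few compounds, and the source may have more. Where it says the series, first, only, none or still open, it means among the compounds named here.

Measured compounds in a functional assay on CHO-K1 cells for antagonist activity at adenosine receptor A1 (Homo sapiens), read by a beta-galactosidase reporter and cAMP accumulation, with stated times of 15 min and 6 h; on this read-out higher numbers stand for weaker inhibition and lower numbers for stronger inhibition:
compound 1, `Nc1nc(-c2ncco2)nc2sc(Cc3ccccc3)cc12`, gives 310 nM.
compound 2, `Cc1csc(-c2nc(N)c3cc(C4(c5ccccc5)CC4)sc3n2)n1`, gives only a limit of the assay, > 610 nM.
compound 3, `N#Cc1cccc(-c2nc(N)c3cc(C4(c5ccccc5)CC4)sc3n2)c1`, gives only a limit of the assay, > 610 nM.

Among the measured compounds shown here, compound 1 holds the only number among the three values; the other two are limits, both sitting at the limit of > 610 nM in this assay, at which 2 of the 3 values shown sit. For the measured compounds named here, the single step between measured compounds, a step that the two limits leave unreadable from compound 2 to compound 3, runs from one limit to another and its size cannot be read, so the series offers no measured step of known size at all.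

Compound 4, `Nc1nc(-c2ccncc2)nc2sc(Cc3ccccc3)cc12`, differs from compound 1 in one place: pyridin-4-yl in place of 1,3-oxazol-2-yl on an aromatic carbon. Going by the values given here, no measured step bears on this exchange. The step that the two limits leave unreadable from compound 2 to compound 3 concerns a different pair of groups and is unreadable in any case. The expectation for compound 4 therefore rests on the value of compound 1 alone, with a wide spread. The expected step in this assay is a 1.6-fold higher number from compound 1 to compound 4 (0.21 log units; within the scatter), a modest shift toward weaker inhibition that is not clearly beyond the scatter. Compound 4 is estimated at 500 nM in this assay, with a range from 150 nM to 2000 nM. Given where the assay limit sits, a limit rather than a number is a real possibility for compound 4.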

Compound 4, inhibition constant: 812 nM
Compound 4: middle estimate off by 1.6-fold (0.21 log units), on the low side, within the range that was stated.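

The exchange on the aromatic carbon between two ring nitrogen atoms now has a readable size in this assay: a 2.6-fold higher number from compound 1 to compound 4 (0.42 log units; beyond the scatter). This makes the ring at this place a measurable influence on the read-out, with the rest of compound 1 unchanged, and the step is beyond the scatter, though modest. Among the compounds shown here, both compounds return numbers, and because the step between compound 2 and compound 3 cannot be read, this pair holds the only readable comparison at this place: the limit of > 610 nM in this assay, at which 2 of the 4 values shown sit.

Left open is how an amine such as morpholine, a carboxylic acid or a longer alkyl chain would read at this place on the core of compound 1, since only two rings, 1,3-oxazol-2-yl and pyridin-4-yl, can be compared there. Also open is whether the exchange from 1,3-oxazol-2-yl to pyridin-4-yl would read the same with the other substituent of compound 2 and compound 3 in place, as no pair shown tests that combination.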